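Extending the Carbamate Chain of an Acyltransferase Inhibitor

The source may report more compounds than this note shows. Statements on the series, on what has been measured and on what is new or still open speak of the compounds shown alone.

A small set of ureas built on one shared core has been examined in an assay on microsomes from intestine for inhibition of acyl-CoA:cholesterol acyltransferase (Oryctolagus cuniculus); a lower number here means a stronger inhibitor, a higher number a weaker inhibitor. Compound 1, `CC(C)c1cccc(C(C)C)c1NC(=O)NC(=O)N1CCCC1`, carries a pyrrolidin-1-yl group on the carbonyl carbon; in this assay compound 1 gives > 5000 nM, which is a limit of the assay and not a number (the limit of > 5000 nM in this assay, at which 1 of the 3 values shown sits). Compound 2, `CCCCN(CCCC)C(=O)NC(=O)Nc1c(C(C)C)cccc1C(C)C`, with dibutylamino on the carbonyl carbon, gives 250 nM. Compound 3, `CCCCCC(C)OC(=O)NC(=O)Nc1c(C(C)C)cccc1C(C)C`, where (1-methylhexyl)oxy sits on the carbonyl carbon, gives 1060 nM; this is the higher of the two numbers, and the step of a 4.2-fold higher number from compound 2 to compound 3 (0.63 log units; beyond the scatter) separates them. Starting from compound 1, the exchange gave an at least 20-fold lower number from compound 1 to compound 2 (1.30 log units; beyond the scatter) and, for the carbamate, an at least 4.7-fold lower number from compound 1 to compound 3 (0.67 log units; beyond the scatter).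

Compound 4, `CCCCCCCC(C)OC(=O)NC(=O)Nc1c(C(C)C)cccc1C(C)C`, differs from compound 3 only by ethyl in place of hydrogen on a saturated chain carbon, six bonds along the chain from an oxygen next to a carbonyl group. None of the three measured steps concerns such a lengthening of a chain; each of them exchanges the whole group on the carbonyl carbon. Among the measured compounds shown here, the only guidance is that the more extended groups of compounds 2 and 3 gave lower numbers than the pyrrolidin-1-yl of compound 1, so a step within the usual scatter, if anything toward a slightly lower number, is expected in this assay. The expected step is a 1.3-fold lower number from compound 3 to compound 4 (0.12 log units; within the scatter). Compound 4 is therefore estimated at 800 nM, with a range from 300 nM to 2500 nM.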

Compound 4, half-maximal inhibitory concentration: 390 nM
For compound 4 the middle estimate is 2.1-fold (0.31 log units) above the measured one, and the stated range covers the measured number.
By their numbers in this assay, from the lowest: compounds 2 and 4 (each within the scatter of the next); then compound 3. At a limit, above all of these: compound 1.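

In this assay, the carbamate chain itself proves to be a place where the number moves: ethyl in place of hydrogen on a saturated chain carbon, six bonds along the chain from an oxygen next to a carbonyl group, gives a 2.7-fold lower number from compound 3 to compound 4 (0.43 log units; beyond the scatter). Among the compounds shown here, each earlier step exchanged the whole group on the carbonyl carbon, so this is the first reading of a change confined to the chain, and it brings the carbamate level with the urea: compound 2 at 250 nM and compound 4 at 390 nM lie within the scatter of each other. Nothing measured here bears on why the chain lengthening lowers the number.

On these data alone, with a single lengthening on record, it remains open whether a still longer chain on the oxygen would lower the number further in this assay or raise it again. As far as these compounds go, it is equally open how an unbranched chain, or a phenyl group in place of the chain, would compare with compound 4, and whether lengthening the butyl chains of compound 2 would produce a similar step.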